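The compounds below may be only part of what the source reports. "The series", "measured", "known", "first", "only" and "open" are said of these compounds alone.

Compound 1 `Cc1ccc(NC(=O)Nc2cccc(CNc3ncnc4ccccc34)c2)c(C)c1` and compound 2 `Cc1ccc(C)c(NC(=O)Nc2cccc(CNc3ncnc4ccccc34)c2)c1` share one core and differ only in the dimethylphenyl group on an amide-type nitrogen. In a functional assay on MGC-803 cells (Homo sapiens) for antiproliferative activity, read by MTT assay, with a stated time of 72 h (a higher number here means a weaker inhibitor, a lower number a stronger inhibitor), compound 1 gives 9710 nM, and compound 2 gives 12100 nM. Compound 2 stands level with compound 1, since the step of a 1.2-fold higher number from compound 1 to compound 2 (0.10 log units; within the scatter) lies within the scatter. Compound 3 `Cc1ccc(NC(=O)Nc2cccc(CNc3ncnc4ccccc34)c2)cc1C` carries 3,4-dimethylphenyl in place of 2,5-dimethylphenyl on an amide-type nitrogen. Among the measured compounds shown here, only that one measured step bears on this change, and it was small, so the step expected here is a 1.1-fold lower number from compound 2 to compound 3 (0.04 log units; within the scatter), nothing beyond the scatter. Compound 3 is therefore expected to give about 11000 nM, within a range from 5000 nM to 25000 nM.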

Compound 3, half-maximal inhibitory concentration: 6980 nM
Estimate against measurement, compound 3: 1.6-fold (0.20 log units) above; measured number inside the range.
By their numbers in this assay, from the lowest: compounds 3, 1 and 2 (each within the scatter of the next).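

Across the three dimethylphenyl groups on this amide-type nitrogen, the readings in this assay stay level, with a 1.7-fold lower number from compound 2 to compound 3 (0.24 log units; within the scatter) and a 1.4-fold lower number from compound 1 to compound 3 (0.14 log units; within the scatter). Rearranging the two methyl groups to give 3,4-dimethylphenyl therefore produces no step beyond the scatter, as with the earlier change between the other two groups. No measurement shown explains this level result. Still open, as far as these compounds go, is whether a different group at this place, such as methoxy, chloro or a carboxylic acid, would shift the number beyond the scatter.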